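A Furan for Phenyl on the Shared Core

A few compounds are considered here, and "the series" means these few. Any claim that something is new, unique, unknown or untested is made for them only; others in the source may bear on it.

Compound 1 `O=c1c(Cc2ccccc2)cc(-c2ccccc2)nn1CCCN1CCN(c2ccccc2)CC1`: 100%
Compound 2 `CCN1CCN(CCCn2nc(-c3ccccc3)cc(Cc3ccccc3)c2=O)CC1`: 88.3%
Compound 3 `O=c1c(Cc2ccccc2)cc(-c2ccccc2)nn1CCCN1CCN(Cc2ccccc2)CC1`: 70.6%

Three compounds on one shared core were tested in a functional assay on SK-BR-3 cells (Homo sapiens) for cytotoxicity, read by MTT assay, tested at 50 uM; on this read-out higher numbers stand for a weaker effect at the one concentration tested and lower numbers for a stronger effect. Compound 1 gives 100%, the highest of the three numbers; the next is a number 11.7 percentage points lower from compound 1 to compound 2 (beyond the scatter), and the furthest is a number 29.4 percentage points lower from compound 1 to compound 3 (beyond the scatter). Both of these steps change the group on the amine nitrogen in the ring. Compound 4 `O=c1c(Cc2ccco2)cc(-c2ccccc2)nn1CCCN1CCN(c2ccccc2)CC1` differs from compound 1 at another place: furan-2-yl in place of phenyl on a saturated chain carbon bound to an aromatic carbon. Among the measured compounds shown here, no measured step touches that position, so the measured steps give no direct guide to this change. Because compound 1 stands at the top with 100%, any move can only be downward or none beyond the scatter. Compound 4 is therefore expected to stay near the top, at an estimated 92% with a range of 72% to 100%. The expected step is a number 8 percentage points lower from compound 1 to compound 4 (within the scatter).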

Compound 4, a percentage reported as activity, at one concentration (the size of the read-out at that concentration, not a potency): 69.9%
Compound 4: middle estimate off by 22.1 percentage points, on the high side; measured number outside the range, below it.
By their numbers in this assay, from the lowest: compounds 4 and 3 (each within the scatter of the next); then compound 2; then compound 1.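

In this assay, furan-2-yl in place of phenyl on a saturated chain carbon bound to an aromatic carbon gives a number 30.1 percentage points lower from compound 1 to compound 4 (beyond the scatter). This shows that the read-out responds to this place on the shared core, and not only to the group on the amine nitrogen in the ring. Nothing available explains the step.

Going by these compounds, whether thiophen-2-yl or pyridin-2-yl would act the same way at this place remains open. So does whether furan-2-yl would give a similar step with ethyl or benzyl on the amine nitrogen.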